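Hydroxyphenyl amide in the toxicity series

The source may hold more compounds than are shown below. What is called first, only, known or untested is meant among the compounds shown, and "the series" means these compounds.

Compound 1, `COc1ccc(C(=O)Nc2ncc(-c3ccc(OC)cc3)n2C)cc1`, is the reference point of this set. In a toxicity assay on THP-1 cells (Homo sapiens) for inhibition (a higher number here means that more compound is tolerated, a lower number that less compound is tolerated), compound 1 gives > 100000 nM, which is a limit of the assay rather than a number. Compound 2, `COc1ccc(-c2ccc(NC(=O)c3ccc(F)cc3)nc2)cc1`, in this assay gives > 100000 nM, again a limit. Both readings thus sit at the limit of > 100000 nM in this assay, at which 2 of the 2 values shown sit. Going by the values given here, no step between measured compounds is available. Compound 3, `COc1ccc(-c2cnc(NC(=O)c3cccc(O)c3)n2C)cc1`, differs from compound 1 by 3-hydroxyphenyl in place of 4-methoxyphenyl on a carbonyl carbon. This change is expected to bring no step beyond the scatter, a number no higher from compound 1 to compound 3 (the limit leaves the size open), in this assay. Compound 3 is therefore expected to give about 100000 nM in this assay, within 50000 nM to 200000 nM, most probably reported again only as a limit.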

Compound 3, half-maximal cytotoxic concentration: > 100000 nM
Compound 3: a limit, no number (the forecaster's own chance of this, stated with the estimate: 75%); the middle value lies on the limit itself.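

No step from compound 1 to compound 3 can be read in this assay, as both readings are limits: the limit of > 100000 nM in this assay, at which 3 of the 3 values shown sit.

The compounds shown leave open what concentration any of them stops being tolerated, and whether 3-hydroxyphenyl in place of 4-methoxyphenyl shifts it.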